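The source may report more compounds than this note shows. Statements on the series, on what has been measured and on what is new or still open speak of the compounds shown alone.

Compound 1 `CN1CCN(c2nc(-c3ccc(Cl)cc3)nc3[nH]cnc23)CC1`: > 80%
Compound 2 `Clc1ccc(Cl)c(-c2nc(N3CCCCC3)c3nc[nH]c3n2)c1`: > 80%

In an assay on cells for displacement of a labelled ligand from adenosine receptor A3 (Homo sapiens), read by scintillation counting and radioligand binding, with a stated time of 180 min, tested at 10 uM (a higher number here means more inhibition at the concentration tested (going by the name of the read-out), a lower number less inhibition), compound 1 is reported only as a limit, > 80%, not as a number. Compound 2 is likewise reported only as a limit, > 80%. Compound 1 thus stands at the limit of > 80% in this assay, at which 2 of the 2 values shown sit. Compound 3 `CN1CCN(c2nc(-c3ccc(O)cc3)nc3[nH]cnc23)CC1` has not yet been measured in this assay; it differs from compound 1 by hydroxy in place of chloro on an aromatic carbon. Among the measured compounds shown here, no measured step exists for that change, so the expectation rests on the position of compound 1 alone. Compound 3 is expected to fall somewhat, with a number at least 20 percentage points lower from compound 1 to compound 3 (beyond the scatter) taken as a moderate downward step. Compound 3 is estimated at 60%, within a range from 30% to 90%.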

Compound 3, a percentage reported as inhibition, at one concentration (the size of the read-out at that concentration, not a potency): 48%
Estimate against measurement, compound 3: 12 percentage points above; measured number inside the range.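

Putting hydroxy in place of chloro on this aromatic carbon, para to a large group, gives a number at least 32 percentage points lower from compound 1 to compound 3 (beyond the scatter) in this assay, so the number is lower with hydroxy at this position than with chloro. Among the compounds shown here, compound 3 also gives the first actual number in the set, whereas the earlier compounds stand only at a limit: the limit of > 80% in this assay, at which 2 of the 3 values shown sit. Going by these compounds, the full size of the step therefore stays unknown.

On these data alone, whether a methoxy group, an amine or a carboxylic acid at this position would keep inhibition or lose more remains open. So does whether the same change would act alike on the core of compound 2.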